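This account rests on a few compounds, and the source may have more. Where it says the series, first, only, none or still open, it means among the compounds named here.

In a functional assay on U-251 cells (Homo sapiens) for inhibition, read by sulforhodamine B assay, with a stated time of 48 h (a higher number here means a weaker inhibitor of growth, a lower number a stronger inhibitor of growth), the measured compounds stand as follows:

compound 1, `COc1ccc(/C=C/C2(C)C=CC(=O)O2)c(OC)c1`, gives 62800 nM
compound 2, `COc1ccc(/C=C/C2(C)C=CC(=O)O2)cc1OC`, gives 193000 nM
compound 3, `COc1cc(/C=C/C2(C)C=CC(=O)O2)cc(OC)c1OC`, gives 125000 nM

Compound 1 and compound 2 contain the same atoms joined differently; the difference between the two cores is not broken down here. Compound 2 gives a higher number than compound 1, and that gap lies beyond the usual scatter. Compound 3 differs from compound 2 by methoxy in place of hydrogen on an aromatic carbon; this change gave a 1.5-fold lower number from compound 2 to compound 3 (0.19 log units; within the scatter). Compound 3 and compound 1 lie within the scatter of each other.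

Compound 4, `COc1cc(OC)c(/C=C/C2(C)C=CC(=O)O2)c(OC)c1`, has not yet been measured in this assay. It differs from compound 1 by methoxy in place of hydrogen on an aromatic carbon. For the measured compounds named here, this is the same kind of change as the one from compound 2 to compound 3, but not the same change: in the step from compound 2 to compound 3 the entering methoxy is ortho to a methoxy group, meta to a group of 9 heavy atoms and meta to a methoxy group, whereas in compound 4 it is ortho to a group of 9 heavy atoms and meta to two methoxy groups.

Going by the values given here, for compound 4 a step of a 1.3-fold lower number from compound 1 to compound 4 (0.10 log units; within the scatter) is expected, resting on the single precedent a 1.5-fold lower number from compound 2 to compound 3 (0.19 log units; within the scatter), which lay within the scatter, and on the different surroundings of the entering methoxy, which leave the direction uncertain. Compound 4 is therefore estimated at 50000 nM, with an expected range from 15000 nM to 160000 nM.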

Compound 4, concentration for total growth inhibition: 193000 nM
For compound 4 the middle estimate is 3.9-fold (0.59 log units) below the measured one, and the stated range ends below it.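

In this assay, methoxy in place of hydrogen on an aromatic carbon, here ortho to a group of 9 heavy atoms and meta to two methoxy groups, gives a 3.1-fold higher number from compound 1 to compound 4 (0.49 log units; beyond the scatter). This change does not carry over as a fixed increment between the two cores: the same change on two cores in this assay, a 1.5-fold lower number (0.19 log units; within the scatter) from compound 2 to compound 3 and a 3.1-fold higher number (0.49 log units; beyond the scatter) from compound 1 to compound 4, 4.7-fold (0.68 log units) apart, beyond the scatter of two such steps. For the compounds shown here, that shows only that one pair cannot be relied on to predict the other; the two pairs differ both in the core and in the surroundings of the entering methoxy, so the data do not separate these two factors, and with a single pair on each core no rule for the series follows.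

The compounds shown leave open whether an amine, a hydroxy group or a longer alkoxy chain at the same aromatic carbon would follow the step seen for methoxy on either core. Going by these compounds alone, they also leave open how methoxy would behave at other places on the aromatic ring, since each core offers only one example of the change.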